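Shortening the side chain of compound 3 toward a hydroxyethyl group

The source may report more compounds than this note shows. Statements on the series, on what has been measured and on what is new or still open speak of the compounds shown alone.

Of the compounds shown here, three sharing one core have been tested in a functional assay on the whole organism (Tail, strain ICR) with Mus musculus as the target, in the tail flick test, with a stated time of 30 min, at a dose of 25 umol/kg by the oral route; a higher number here means a stronger effect of the compound at the dose given, a lower number a weaker effect. Compound 1 `NC(=O)CC[C@H](NC(=O)CN(c1ncnc2c1ncn2C1CCCCO1)C1CC1)C(=O)OCc1ccccc1` gives 47%, compound 2 `O=C(CN(c1nc(Cl)nc2[nH]cnc12)C1CC1)NCC(=O)OCc1ccccc1` gives 18.7%, and compound 3 `O=C(CN(c1ncnc2c1ncn2C1CCCCO1)C1CC1)N[C@@H](CCC(=O)OCc1ccccc1)C(=O)OCc1ccccc1` gives 32.6%. Compound 3 therefore holds the second highest of the three numbers, with compound 2 beyond the scatter below it and compound 1 beyond the scatter above it.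

Compound 4 `C[C@@H](O)[C@H](NC(=O)CN(c1ncnc2c1ncn2C1CCCCO1)C1CC1)C(=O)OCc1ccccc1` differs from compound 3 in one place: 1-hydroxyethyl in place of 2-(benzyloxycarbonyl)ethyl on a saturated chain carbon bound to an amide-type nitrogen and a carbonyl carbon. For the measured compounds named here, the only measured step that touches this region is a number 14.4 percentage points lower from compound 1 to compound 3 (beyond the scatter), where a benzyloxy group on the carbonyl carbon replaced an amino group. Compound 4 removes that benzyl ester chain altogether and brings in a small group carrying one hydrogen-bond donor, which resembles the amide of compound 1 more than the ester of compound 3.

On this slender basis a modest rise is expected, a number 9.4 percentage points higher from compound 3 to compound 4 (within the scatter), partly because a number 14.4 percentage points lower from compound 1 to compound 3 (beyond the scatter) ran the other way when the ester was introduced. Compound 4 is estimated at 42%, with a range from 25% to 60%.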

Compound 4, a percentage reported as activity, at one dose (the size of the read-out at that dose, not a potency): 23.6%
The estimate for compound 4 lay 18.4 percentage points above the measured number; the whole stated range lies above it.
By their numbers in this assay, from the lowest: compounds 2, 4 and 3 (each within the scatter of the next, the first and the last beyond it); then compound 1.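

In this assay, putting 1-hydroxyethyl, with 3 heavy atoms, in place of 2-(benzyloxycarbonyl)ethyl, with 12 heavy atoms and an aromatic ring, gives a number 9 percentage points lower from compound 3 to compound 4 (within the scatter), so this large change at this position leaves no readable difference. Against the 2-carbamoylethyl group, the same small group gives a number 23.4 percentage points lower from compound 1 to compound 4 (beyond the scatter), which shows that the choice of group at this position can matter and that 1-hydroxyethyl, despite its hydrogen-bond donor, does not match 2-carbamoylethyl. No measurement is available to explain these results.

The compounds shown leave open whether the higher number for compound 1 depends on the amide itself or on the length of its chain, since 1-hydroxyethyl differs in both. A 2-hydroxyethyl group, a carboxylic acid or an amine at this position would help separate these two possibilities.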